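The source may report more compounds than this note shows. Statements on the series, on what has been measured and on what is new or still open speak of the compounds shown alone.

Measured compounds:
- Compound 1, `CCN(Cc1cccs1)C(=O)COc1ccc(C)cc1`: in an assay on HEK293 cells for agonist activity at transient receptor potential cation channel subfamily M member 8 (Homo sapiens), read by fluorescence and calcium flux, with a stated time of 15 min (on this read-out lower numbers stand for an effect already at smaller amounts and higher numbers for an effect only at larger amounts of compound), compound 1 gives 8 nM.
- Compound 2, `Cc1ccc(OCC(=O)N(Cc2cccs2)c2ccn(C)n2)cc1`: compound 2 gives 855 nM.
- Compound 3, `CCC(C)N(Cc1cccs1)C(=O)COc1ccc(C)cc1`: compound 3 gives 2000 nM.

Compound 1 has the lowest number of the three. The steps of a 110-fold higher number from compound 1 to compound 2 (2.03 log units; beyond the scatter) and a 250-fold higher number from compound 1 to compound 3 (2.40 log units; beyond the scatter) both run far beyond the scatter, while a 2.3-fold higher number from compound 2 to compound 3 (0.37 log units; beyond the scatter) is modest. All three measured steps change the group on the amide nitrogen; the aryl ring bearing the methyl stays the same throughout the measured set.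

Compound 4, `CCN(Cc1cccs1)C(=O)COc1ccc(C(C)C)cc1`, differs from compound 1 only on that ring: isopropyl in place of methyl on an aromatic carbon. For the measured compounds named here, no measured pair varies this ring, so none of the three steps bears directly on the change; the large steps seen so far arise at the other end of the molecule and give no guidance for this position. With nothing in the series pointing either way, a small step is the working expectation, with the range widened to cover the lack of any precedent. The number for compound 4 is expected to be 15 nM, with a range of 3 nM to 80 nM. The step this estimate implies is expected to lie within the scatter: a 1.9-fold higher number from compound 1 to compound 4 (0.27 log units; within the scatter).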

Compound 4, half-maximal effective concentration: 397 nM
Beside the measured number, compound 4's estimate is 26-fold (1.42 log units) below it, and the stated range ends below it.
By their numbers in this assay, from the lowest: compound 1; then compound 4; then compound 2; then compound 3.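

In this assay the aromatic carbon carrying the methyl of compound 1 proves sensitive: isopropyl in place of methyl gives a 50-fold higher number from compound 1 to compound 4 (1.70 log units; beyond the scatter) and so counts as a large step. The series therefore responds strongly at this end of the molecule as well as at the amide nitrogen, and it does so with a change that brings in no ring, hydrogen-bond donor, hydrogen-bond acceptor or net charge. Nothing at hand explains the size of this step.

On these data alone, it remains open whether hydrogen, chlorine or methoxy at this carbon would keep a number close to that of compound 1, or whether any larger group gives a similar step. Also open, as far as these compounds go, is whether isopropyl has the same effect when sec-butyl or 1-methyl-1H-pyrazol-3-yl sits on the amide nitrogen.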